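Cytotoxicity of a Piperidinyl Analogue in Fibroblast Cells

A few compounds are considered here, and "the series" means these few. Any claim that something is new, unique, unknown or untested is made for them only; others in the source may bear on it.

Measured so far:
compound 1, `COC(=O)c1ccc(NCc2cncn2Cc2cccc(Cl)c2)cc1-c1ccccc1` — > 10000 nM
compound 2, `O=C(OC1CCCCC1)c1ccc(NCc2cncn2Cc2ccc(-c3ccccc3)cc2)cc1-c1ccccc1` — > 10000 nM

Of the compounds shown here, two have been tested in a toxicity assay on NIH3T3 cells (Mus musculus) for cytotoxicity, read by resazurin assay; on this read-out lower numbers stand for an effect already at smaller amounts and higher numbers for an effect only at larger amounts of compound. For compound 1 the result is not a number but a limit of the assay, > 10000 nM. For compound 2 the result is likewise a limit, > 10000 nM. Both values therefore sit at the limit of > 10000 nM in this assay, at which 2 of the 2 values shown sit, so neither compound shows a measurable effect within the tested range, and nothing distinguishes the two.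

Compound 3, `c1ccc(-c2ccc(Cn3cncc3CNc3ccc(N4CCCCC4)c(-c4ccccc4)c3)cc2)cc1`, has not yet been measured. It differs from compound 2 in one place: piperidin-1-yl in place of cyclohexyloxycarbonyl on an aromatic carbon. The rest of the molecule is unchanged.

For the measured compounds named here, with both measured compounds resting at the limit, there is no measured step to lean on, and no effect within the tested range is yet known for this series. The expected step from compound 2 to compound 3 is a step that the limit leaves unreadable from compound 2 to compound 3, that is none beyond the scatter. Compound 3 is estimated to give 12000 nM in this assay, within a range from 3000 nM to 40000 nM, most likely reported again only as a limit.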

Compound 3, half-maximal effective concentration: > 1000 nM
Compound 3: only a limit was reported; the forecaster's own chance of this, stated with the estimate: 70%; the middle value lies beyond the limit too.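

In this assay compound 3 gives > 1000 nM, a limit of the assay and not a number. Compound 2 also rests at a limit, so no step can be read between compound 2 and compound 3. The compounds shown leave open whether piperidin-1-yl in place of cyclohexyloxycarbonyl changes cytotoxicity at all, and at what concentration any of them would show an effect.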